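Swapping the ring on a dithiocarbamate: morpholine to pyrrolidine

The source may hold more compounds than are shown below. What is called first, only, known or untested is meant among the compounds shown, and "the series" means these compounds.

Measured compounds:
compound 1, `O=c1c(CSC(=S)N2CCCC2)coc2ccccc12`, 3800 nM in a functional assay on MDA-MB-435S cells (Homo sapiens) for antiproliferative activity, read by MTT assay, with a stated time of 72 h; on this read-out higher numbers stand for weaker inhibition and lower numbers for stronger inhibition
compound 2, `COc1ccc2occ(CSC(=S)N3CCOCC3)c(=O)c2c1`, > 40000 nM

Compound 2 gives no number in this assay but only a limit, > 40000 nM. On the values shown, compound 2 therefore stands at the weak end, a position marked by the limit of > 40000 nM in this assay, at which 1 of the 2 values shown sits. Compound 3, `COc1ccc2occ(CSC(=S)N3CCCC3)c(=O)c2c1`, is not yet measured. It differs from compound 2 in one place: pyrrolidin-1-yl in place of morpholin-4-yl on a thiocarbonyl carbon. Because compound 2 sits at the limit of > 40000 nM in this assay, at which 1 of the 2 values shown sits, the true size of the step cannot be read from that side; only the direction can be expected, toward stronger inhibition, and the estimated step of an at least 4.0-fold lower number from compound 2 to compound 3 (0.60 log units; beyond the scatter) is offered with this caution. Among the compounds with values here, the expectation leans on the one numerical value in the set, compound 1 at 3800 nM. Compound 3 is expected at 10000 nM, with a range from 3000 nM to 40000 nM.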

Compound 3, half-maximal inhibitory concentration: 1800 nM
For compound 3 the middle estimate is 5.6-fold (0.74 log units) above the measured one; the measured number lies below the stated range.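

In this assay, within the data shown here, replacing morpholin-4-yl with pyrrolidin-1-yl on a thiocarbonyl carbon, with everything else kept, gives an at least 22-fold lower number from compound 2 to compound 3 (1.34 log units; beyond the scatter), the first comparison that isolates this ring from the rest of the molecule. That step is only a minimum, because compound 2 gives a limit and not a number: the limit of > 40000 nM in this assay, at which 1 of the 3 values shown sits. Methoxy in place of hydrogen on an aromatic carbon, with pyrrolidin-1-yl kept, gives a 2.1-fold lower number from compound 1 to compound 3 (0.32 log units; beyond the scatter), a modest gain beside the ring swap.

The swap changes ring size and removes the ring oxygen together, and the compounds shown cannot tell which of the two matters. Piperidin-1-yl, a six-membered ring without the oxygen, would separate them, while an open-chain diethylamino group would test whether a ring is needed at all.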